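A few compounds are considered here, and "the series" means these few. Any claim that something is new, unique, unknown or untested is made for them only; others in the source may bear on it.

Working notes on the series. Compound 1 `NS(=O)(=O)c1ccc(Nc2ncc(F)c(Nc3nc4ccc(Cl)cc4s3)n2)cc1` is the reference point. Going by the values given here, in a functional assay on MCF7 cells (Homo sapiens) for antiproliferative activity, read by MTT assay, with a stated time of 48 h (a lower number here means a stronger inhibitor, a higher number a weaker inhibitor), compound 1 gives 8340 nM, the only number obtained so far among the three compounds measured. The other two sit at the limit of the method, (the limit of > 50000 nM in this assay, at which 2 of the 3 values shown sit). Compound 2 `Cc1cnc(Nc2ccc(S(N)(=O)=O)cc2)nc1Nc1nc2ccc(F)cc2s1` reaches only a limit in this assay, reported as > 50000 nM. Compound 3 `Cc1ccc2nc(Nc3nc(Nc4ccc(S(C)(=O)=O)cc4)ncc3F)sc2c1` likewise reaches only a limit in this assay, reported as > 50000 nM. Among the compounds with values here, since both of these values are limits and not numbers, no step between measured compounds can be stated, and compound 1 stands alone as the sole anchor.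

Compound 4 `COc1ccc2nc(Nc3nc(Nc4ccc(S(N)(=O)=O)cc4)ncc3F)sc2c1` has not yet been measured. It differs from compound 1 in one place: methoxy in place of chloro on an aromatic carbon. Within the data shown here, with no measured step of this kind available, the expectation for compound 4 in this assay rests on compound 1 alone and on its value of 8340 nM. A small shift toward weaker inhibition is expected, a 1.4-fold higher number from compound 1 to compound 4 (0.16 log units; within the scatter), a step that may well lie within the scatter. For compound 4 the estimated value in this assay is 12000 nM, with a range from 4000 nM to 40000 nM.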

Compound 4, half-maximal inhibitory concentration: > 50000 nM
Compound 4: a limit, no number; the forecaster's own chance of this, stated with the estimate: 25%; middle value at least 4.1-fold (0.61 log units) away from the limit.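

Going by these compounds alone, at this place on the six-membered aromatic ring of the fused system, methoxy in place of chloro gives the first readable step: an at least 5.9-fold higher number from compound 1 to compound 4 (0.77 log units; beyond the scatter). From the compounds shown here alone, compound 4 sits at a limit and not at a number, so the step gives only a bound and its full size stays unknown. In this assay, compound 1 remains the only compound with a number, and this single change at this place is enough to lose it: the limit of > 50000 nM in this assay, at which 3 of the 4 values shown sit.

Going by these compounds, it remains open whether chloro itself is needed or whether another group here, such as bromo, an amine or trifluoromethyl, would keep a number in this assay. Compound 2 and compound 3 each differ from compound 1 in more than one place, leaving the contribution of each of those other places unresolved.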